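Adding a chloro group to compound 2

The compounds below may be only part of what the source reports. "The series", "measured", "known", "first", "only" and "open" are said of these compounds alone.

- compound 1 (`C[C@@H](Cn1ccc(-c2ccc(C#N)c(Cl)c2)n1)Nc1ccncc1`) gives 11500 nM
- compound 2 (`C[C@@H](Cn1ccc(-c2ccc(C#N)c(Cl)c2)n1)Nc1ncccn1`) gives 12500 nM

In a functional assay on CWR22R cells (Homo sapiens) for antiproliferative activity, read by CCK-8 assay, with a stated time of 6 days (a higher number here means a weaker inhibitor, a lower number a stronger inhibitor), compound 2 gives 12500 nM, level with compound 1. Compound 3 (`C[C@@H](Cn1ccc(-c2ccc(C#N)c(Cl)c2)n1)Nc1nccc(Cl)n1`) differs from compound 2 by one change, (chloro in place of hydrogen on an aromatic carbon), chloro in place of hydrogen on an aromatic carbon, so pyrimidin-2-yl becomes 4-chloropyrimidin-2-yl. Among the compounds with values here, the only measured step nearby is a 1.1-fold higher number from compound 1 to compound 2 (0.04 log units; within the scatter), and it swaps one ring for another and does not test a chloro group. No step beyond the scatter is therefore expected in this assay, and no direction can be favoured. The estimated step is a 1.3-fold lower number from compound 2 to compound 3 (0.10 log units; within the scatter). For compound 3 the expected value is 10000 nM, with an estimated range of 4000 nM to 22000 nM.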

Compound 3, half-maximal inhibitory concentration: > 30000 nM
Compound 3: only a limit was reported; the forecaster's own chance of this, stated with the estimate: 10%; middle value at least 3.0-fold (0.47 log units) from the limit.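

In this assay compound 3 gives > 30000 nM, which is a limit and not a number. The earlier ring swap stayed within the scatter, whereas the 4-chloropyrimidin-2-yl group gives steps beyond it: an at least 2.4-fold higher number from compound 2 to compound 3 (0.38 log units; beyond the scatter) and an at least 2.6-fold higher number from compound 1 to compound 3 (0.41 log units; beyond the scatter). So this position, next to the ring nitrogen, responds to a single chloro group, but the full size of both steps stays unknown because the reading ends at a limit: the limit of > 30000 nM in this assay, at which 1 of the 3 values shown sits.

As far as these compounds go, how a methyl, a methoxy or an amine at this position would read stays open. So does whether a chloro group on the pyridin-4-yl ring of compound 1 would shift the number the same way.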